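The compounds below may be only part of what the source reports. "The series", "measured", "known", "first", "only" and "open" are said of these compounds alone.

Series notes. Compound 1 `O=C(Nc1cc(-c2ccccc2)[nH]n1)c1cncc(Br)c1` gives 8120 nM in a functional assay on A-375 cells (Homo sapiens) for antiproliferative activity, read by MTT assay, with a stated time of 48 h; on this read-out lower numbers stand for stronger inhibition and higher numbers for weaker inhibition. Compound 2 `O=C(Nc1cc(-c2ccccc2)[nH]n1)c1ccc(Br)nc1` gives 8870 nM in this assay; the change from compound 1 is 6-bromopyridin-3-yl in place of 5-bromopyridin-3-yl on a carbonyl carbon, and the step is a 1.1-fold higher number from compound 1 to compound 2 (0.04 log units; within the scatter). Compound 3 `Cc1ccc(-c2cc(NC(=O)c3cncc(Br)c3)n[nH]2)cc1` gives 7050 nM; its core differs from that of compound 1 by methyl in place of hydrogen on an aromatic carbon, with a step of a 1.2-fold lower number from compound 1 to compound 3 (0.06 log units; within the scatter). All three numbers sit within the usual scatter of one another, so no order among them is claimed.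

Compound 4 `Cc1ccc(-c2cc(NC(=O)c3ccc(Br)nc3)n[nH]2)cc1` is not yet measured. It differs from compound 3 by 6-bromopyridin-3-yl in place of 5-bromopyridin-3-yl on a carbonyl carbon, the same change seen from compound 1 to compound 2, at the same place. The step from compound 3 to compound 4 is expected to be a 1.1-fold higher number from compound 3 to compound 4 (0.04 log units; within the scatter), resting on the step of a 1.1-fold higher number from compound 1 to compound 2 (0.04 log units; within the scatter). Compound 4 is therefore estimated at 7700 nM, with a range from 4500 nM to 13000 nM.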

Compound 4, half-maximal inhibitory concentration: 7670 nM
Compound 4: middle estimate off by 1.0-fold (0.00 log units), on the high side; the range from low to high includes it.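

On the core of compound 3, 6-bromopyridin-3-yl in place of 5-bromopyridin-3-yl gives a 1.1-fold higher number from compound 3 to compound 4 (0.04 log units; within the scatter), which matches the same change on the core of compound 1: the same change on two cores in this assay, a 1.1-fold higher number (0.04 log units; within the scatter) from compound 1 to compound 2 and a 1.1-fold higher number (0.04 log units; within the scatter) from compound 3 to compound 4, 1.0-fold (0.00 log units) apart, within the scatter of two such steps

In this assay, methyl in place of hydrogen on an aromatic carbon gives a 1.2-fold lower number from compound 2 to compound 4 (0.06 log units; within the scatter), which also matches the earlier step: the same change on two cores in this assay, a 1.2-fold lower number (0.06 log units; within the scatter) from compound 1 to compound 3 and a 1.2-fold lower number (0.06 log units; within the scatter) from compound 2 to compound 4, 1.0-fold (0.00 log units) apart, within the scatter of two such steps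

For the compounds shown here, every step here lies within the scatter, so the match shows only that neither change moves the number measurably on these two cores, not that a step of real size would carry from one core to another.

The compounds shown leave open whether an amine or a carboxylic acid in place of the bromine would move the number beyond the scatter. The same holds for a longer chain in place of the methyl.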